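Replacing pyridin-3-yl with anilino: what to expect for compound 3

The source may hold more compounds than are shown below. What is called first, only, known or untested is meant among the compounds shown, and "the series" means these compounds.

Measured so far in a functional assay on HeLa cells (Homo sapiens) for cytotoxicity, read by resazurin assay, with a stated time of 72 h; a lower number here means a stronger inhibitor, a higher number a weaker inhibitor:
- compound 1 (`CCSC(=S)SCC(=O)c1ccc(NS(C)(=O)=O)cc1`) – 45800 nM
- compound 2 (`CCSC(=S)SCC(=O)c1ccc(NC(=O)c2cccnc2)cc1`) – 5160 nM

Compound 2 has the lower of the two numbers at 5160 nM and so is the stronger inhibitor of the pair. Compound 3 (`CCSC(=S)SCC(=O)c1ccc(NC(=O)Nc2ccccc2)cc1`) keeps its core but carries anilino in place of pyridin-3-yl on a carbonyl carbon. For the measured compounds named here, only one measured step bears on this, the swap of methylsulfonyl for (pyridin-3-yl)carbonyl on a nitrogen on an aromatic ring. Compound 2 and compound 3 both keep a carbonyl on that nitrogen, so a step smaller than the modest 8.9-fold lower number from compound 1 to compound 2 (0.95 log units; beyond the scatter) is expected, with no direction that the data settle. The expected result in this assay is a 1.1-fold lower number from compound 2 to compound 3 (0.06 log units; within the scatter) and it may well stay within the scatter. For compound 3 the estimated value is 4500 nM with an expected range from 1600 nM to 13000 nM in this measurement.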

Compound 3, half-maximal inhibitory concentration: 20200 nM
Beside the measured number, compound 3's estimate is 4.5-fold (0.65 log units) below it; the measured number lies above the stated range.
By their numbers in this assay, from the lowest: compound 2; then compound 3; then compound 1.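

In this assay, the group on the carbonyl carbon matters even when the carbonyl itself stays in place: anilino in place of pyridin-3-yl gives a 3.9-fold higher number from compound 2 to compound 3 (0.59 log units; beyond the scatter). The earlier step replaced the whole methylsulfonyl group on the nitrogen, so it could not show that a change on the carbonyl carbon alone still moves the number beyond the usual scatter. Nothing measured here explains this loss of strength, and the extra hydrogen-bond donor that anilino brings remains a structural difference only.

Still open, from the compounds shown here alone, is whether the higher number goes with the nitrogen that anilino places on the carbonyl carbon or with the carbon-only ring; a phenyl group at that place would separate the two. Also open, going by these compounds, is how a non-aromatic group, such as dimethylamino, would read there.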